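This account rests on a few compounds, and the source may have more. Where it says the series, first, only, none or still open, it means among the compounds named here.

Compound 1 `CCCCCc1ccc2nc(O)oc2c1` gives 80.7 mg/kg in a functional assay on the whole organism for inhibition, with Mus musculus as the target; a lower number here means that less compound is needed, a higher number that more compound is needed for the effect. Compound 2 `CCC(=O)c1ccc2c(c1)sc(=O)n2CCN1CCCC1` gives only a limit of this assay, reported as > 80 mg/kg. Compound 3 `CCC(=O)c1ccc2c(c1)oc(=O)n2CCN1CCCCC1` likewise gives only a limit, reported as > 100 mg/kg. Among the three values shown, compound 2 therefore sits at the limit of > 80 mg/kg in this assay, at which 1 of the 3 values shown sits, while compound 3 sits at the limit of > 100 mg/kg in this assay, at which 1 of the 3 values shown sits; neither is a number. Compound 4 `CCC(=O)c1ccc2c(c1)sc(=O)n2CCN1CCCCC1` has not been measured; it differs from compound 2 by piperidin-1-yl in place of pyrrolidin-1-yl on a saturated chain carbon, two bonds along the chain from an aromatic nitrogen. Among the measured compounds shown here, no step between measured compounds is available, and compound 3 already carries the piperidin-1-yl group on a different core without leaving its limit. The step that the limit leaves unreadable from compound 2 to compound 4 is expected to be none beyond the usual scatter. Compound 4 is thus estimated at about 120 mg/kg, within 60 mg/kg to 300 mg/kg, most probably again as a limit.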

Compound 4, dose for half-maximal effect: > 55 mg/kg
Compound 4: only a limit was reported; the forecaster's own chance of this, stated with the estimate: 75%; the middle value does not contradict the limit.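

Among the compounds shown here, compound 2 and compound 4 are both reported only as limits in this assay, so no step between them can be read. The compounds shown leave open whether piperidin-1-yl in place of pyrrolidin-1-yl changes the dose needed.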